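A few compounds are considered here, and "the series" means these few. Any claim that something is new, unique, unknown or untested is made for them only; others in the source may bear on it.

Compound 1 `C/C=C/C(=O)Nc1cc2c(N3CCc4ccccc43)ncnc2cc1OC`: 8120 nM
Compound 2 `C/C=C/C(=O)Nc1cc2c(N3CCc4ccccc43)ncnc2cc1O[C@@H]1CCOC1`: 5220 nM
Compound 3 `CC(C)=CC(=O)Nc1cc2c(N3CCCc4ccccc43)ncnc2cc1O[C@@H]1CCOC1`: 9020 nM

All three were tested in a functional assay on PC-3 cells (Homo sapiens) for antiproliferative activity, read by MTT assay, with a stated time of 72 h; a higher number here means a weaker inhibitor, a lower number a stronger inhibitor. Compound 1 sits in the middle of the three numbers, yet every gap is small: the step of a 1.6-fold lower number from compound 1 to compound 2 (0.19 log units; within the scatter) is within the usual scatter, and the number of compound 3 lies even closer to that of compound 1, so the three cannot be ranked against each other.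

Compound 4 `COc1cc2ncnc(N3CCc4ccccc43)c2cc1NC(=O)/C=C/CN1CCCCC1` keeps the shared core of compound 1 and changes only the amide chain: piperidin-1-yl in place of hydrogen on a saturated chain carbon bound to a double-bonded chain carbon. For the measured compounds named here, no measured pair speaks to this part of the molecule. Going by the values given here, the one single-point step, from compound 1 to compound 2, alters the ether group on the aromatic ring, and the step from compound 2 to compound 3 alters two places at once, so neither reaches the chain that is extended here. With the measured steps all falling within the scatter, nothing in these data points to a large move in either direction; the expected step of a 1.5-fold lower number from compound 1 to compound 4 (0.17 log units; within the scatter) is therefore modest, with a wide band around it. For compound 4 the estimate in this assay is 5500 nM, with a range from 1800 nM to 16000 nM.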

Compound 4, half-maximal inhibitory concentration: 4180 nM
Compound 4: the middle estimate sits 1.3-fold (0.12 log units) above what was measured; low and high end bracket the measured number.
By their numbers in this assay, from the lowest: compounds 4, 2, 1 and 3 (each within the scatter of the next, the first and the last beyond it).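

For the compounds shown here, the earlier steps reached only the ether group on the aromatic ring, so this is the first reading from the amide chain. In this assay, putting piperidin-1-yl on a saturated chain carbon bound to a double-bonded chain carbon gives a 1.9-fold lower number from compound 1 to compound 4 (0.29 log units; within the scatter) and so shows that a whole six-membered ring containing a nitrogen can be added at this chain carbon without the number leaving the scatter of compound 1, although that single step cannot show a real gain in activity. No measurement here offers an explanation for this result.

As far as these compounds go, whether a smaller amine such as dimethylamino, or a ring with a second hetero atom such as morpholin-4-yl, would give a step of another size on the same saturated chain carbon remains open. Also open, from the compounds shown here alone, is whether piperidin-1-yl would give a similar step with the oxolan-3-yl group of compound 2 in place of the methyl on the oxygen, since changes at the two places have each been read only on their own.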